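The compounds below may be only part of what the source reports. "The series", "measured", "known", "first", "only" and "open" are said of these compounds alone.

The measured compounds in an assay for inhibition of MAP kinase-interacting serine/threonine-protein kinase 2 (Homo sapiens), read by luminescence and ADP-Glo, with a stated time of 2 h; on this read-out higher numbers stand for weaker inhibition and lower numbers for stronger inhibition:
compound 1, `Nc1n[nH]c2cc(-c3ccc(=O)n(Cc4cccc(Cl)c4)c3)ccc12`, gives 6 nM;
compound 2, `O=c1ccc(-c2ccc3cn[nH]c3c2)cn1Cc1cccc(C(F)(F)F)c1`, gives 32 nM;
compound 3, `O=c1ccc(-c2ccc3cn[nH]c3c2)cn1Cc1ccccc1`, gives 75 nM.

Compound 1 stands at the lowest of the three numbers. Compound 2 is its nearest neighbour, and compound 3 the furthest; both of these lack the amino group on the shared core and carry a different substituent on the benzyl group, so each differs from compound 1 in more than one place and only their values can be compared.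

Compound 4 is `Nc1n[nH]c2cc(-c3ccc(=O)n(Cc4cccc(F)c4)c3)ccc12`. It differs from compound 1 in one place: fluoro in place of chloro on an aromatic carbon.

For the measured compounds named here, only one single-point step is available, a 2.3-fold higher number from compound 2 to compound 3 (0.37 log units; beyond the scatter), and it does not involve chloro or fluoro at all; it shows that removing trifluoromethyl from the benzyl group costs a modest amount. It bears on the present change only by analogy, as another substituent change on an aromatic carbon of the benzyl group. A halogen swap is a smaller change than removing a group altogether, so the expected step is small and upward at most, a 1.7-fold higher number from compound 1 to compound 4 (0.22 log units; within the scatter). For compound 4 the estimated value is 10 nM, with a range from 4 nM to 25 nM.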

Compound 4, half-maximal inhibitory concentration: 5 nM
Compound 4: middle estimate off by 2.0-fold (0.30 log units), on the high side; the range from low to high includes it.
By their numbers in this assay, from the lowest: compounds 4 and 1 (each within the scatter of the next); then compound 2; then compound 3.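

In this assay the exchange of 3-chlorobenzyl for 3-fluorobenzyl gives a 1.2-fold lower number from compound 1 to compound 4 (0.08 log units; within the scatter) and so leaves the reading unchanged within the scatter, which means that chloro and fluoro cannot be told apart at this place on the amino-bearing core. For the compounds shown here, this is the first comparison in one place on that core, whereas the earlier step of a 2.3-fold higher number from compound 2 to compound 3 (0.37 log units; beyond the scatter) belongs to compounds without the amino group and concerns trifluoromethyl and hydrogen rather than two halogens. No measurement at hand accounts for this result.

From the compounds shown here alone, it remains open whether hydrogen, trifluoromethyl, or a different group such as methoxy, an amine or a carboxylic acid at this place on the benzyl group would read as closely on the amino-bearing core as chloro and fluoro do. The share of the amino group in the gap between these two compounds and compound 2 or compound 3 also stays open, since no pair shown differs in that group alone.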